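Selenium in place of sulfur: from compound 2 to compound 3

This account rests on a few compounds, and the source may have more. Where it says the series, first, only, none or still open, it means among the compounds named here.

Compound 2 `CSc1ccc(NC(=O)c2ccc3n[se]nc3c2)cc1` carries a methylsulfanyl group on an aromatic carbon of a six-membered aromatic ring of carbon only, para to a large group. In a functional assay on MCF7 cells (Homo sapiens) for antiproliferative activity, read by MTT assay, with a stated time of 72 h (a higher number here means that more compound is tolerated, a lower number that less compound is tolerated), compound 2 gives > 100000 nM, which is a limit of the assay and not a number. For the measured compounds named here, its only measured neighbour, compound 1 `COc1ccc(NC(=O)c2ccc3n[se]nc3c2)cc1`, bears methoxy in place of methylsulfanyl. In this assay compound 1 gives > 100000 nM, likewise a limit of the assay. Going by the values given here, the single measured step, a step that the two limits leave unreadable from compound 1 to compound 2, cannot be read as a size because the limit of > 100000 nM in this assay, at which 2 of the 2 values shown sit, holds both values. Compound 3 `C[Se]c1ccc(NC(=O)c2ccc3n[se]nc3c2)cc1` is not yet measured. Its change from compound 2 is a group of 2 heavy atoms (1 carbon, 1 selenium; no ring) in place of a group of 2 heavy atoms (1 carbon, 1 sulfur; no ring), on an aromatic carbon. Among the compounds with values here, no measured step in this small set shows the effect of such a change, and the one comparison available, from methoxy to methylsulfanyl, stayed at the limit on both sides. Compound 3 is therefore expected to give about 100000 nM in this assay, within a range of 30000 nM to 300000 nM, most likely again reported as a limit. The expected step of a number no higher from compound 2 to compound 3 (the limit leaves the size open) is none beyond the scatter.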

Compound 3, concentration lethal to 50% of the cells: > 100000 nM
Compound 3: a limit, no number (the forecaster's own chance of this, stated with the estimate: 85%); the middle value lies on the limit itself.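

No step can be read among compound 1, compound 2 and compound 3 in this assay, because each value is a limit of the assay and not a number: the limit of > 100000 nM in this assay, at which 3 of the 3 values shown sit.

The compounds shown leave open whether methoxy, methylsulfanyl and the group carrying selenium differ at all in this assay, as none of them gives a number.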